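A few compounds are considered here, and "the series" means these few. Any claim that something is new, unique, unknown or untested is made for them only; others in the source may bear on it.

Working notes on the permeability of the series. Compound 1 `Cc1c(CCCC(=O)O)c2cccc(/C=C/c3ccc(OCCCCc4ccccc4)cc3)c2n1CC(=O)O` carries the unsubstituted phenyl at the end of the chain. In a physicochemical assay for permeability, using PAMPA, with a stated time of 4 h, at pH 7.4, tested at 50 uM (on this read-out lower numbers stand for lower permeability and higher numbers for higher permeability), compound 1 returns only a limit, < 0.05 10^-6 cm/s. Compound 2 `Cc1c(Cl)cccc1CCCCOc1ccc(C#Cc2cccc3c(CCCC(=O)O)c(C)n(CC(=O)O)c23)cc1`, the alkyne analogue with a chlorinated methylphenyl, gives 3.2 10^-6 cm/s in this assay. Compound 3 `Cc1c(CCCC(=O)O)c2cccc(/C=C/c3ccc(OCCCCc4c(F)c(F)cc(F)c4F)cc3)c2n1CC(=O)O` gives 0.5 10^-6 cm/s in this assay, the lowest of the two numbers reported; compound 2 is the nearest neighbour and lies above it, beyond the scatter. Going by the values given here, the single step that involves compound 3 is an at least 10-fold higher number from compound 1 to compound 3 (1.00 log units; beyond the scatter), and it starts from a limit (the limit of < 0.05 10^-6 cm/s in this assay, at which 1 of the 3 values shown sits), so its true size is not fixed.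

Compound 4 `Cc1c(CCCC(=O)O)c2cccc(/C=C/c3ccc(OCCCCc4c(F)cc(F)c(F)c4F)cc3)c2n1CC(=O)O` is the positional isomer next in line; the change is 2,3,4,6-tetrafluorophenyl in place of 2,3,5,6-tetrafluorophenyl on a saturated chain carbon, four bonds along the chain from an oxygen on an aromatic ring. Among the compounds with values here, the only measured step at this position is the exchange of phenyl for tetrafluorophenyl, which was at least modest in this assay. Nothing measured moves a fluorine around the ring while keeping the count; a shift of the pattern alone, with the same atoms joined differently, is therefore expected to give a step within the scatter, no change at the digits printed from compound 3 to compound 4 (within the scatter). Compound 4 is estimated at 0.5 10^-6 cm/s in this assay, between 0.2 10^-6 cm/s and 1.2 10^-6 cm/s.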

Compound 4, apparent permeability: 0.3 10^-6 cm/s
Compound 4: the middle estimate sits 1.7-fold (0.22 log units) above what was measured, and the stated range covers the measured number.
By their numbers in this assay, from the lowest: compounds 4 and 3 (each within the scatter of the next); then compound 2. At a limit, below all of these: compound 1.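

Working from the same position, on a saturated chain carbon, four bonds along the chain from an oxygen on an aromatic ring, the series now holds a change of fluorine pattern alone: in this assay, 2,3,4,6-tetrafluorophenyl in place of 2,3,5,6-tetrafluorophenyl gives a 1.7-fold lower number from compound 3 to compound 4 (0.22 log units; within the scatter), so this read-out does not separate the two patterns. The step from the unsubstituted phenyl also recurs with the second pattern, as an at least 6.0-fold higher number from compound 1 to compound 4 (0.77 log units; beyond the scatter), which means that it no longer rests on compound 3 alone. This step starts from a limit, so its true size is not fixed: the limit of < 0.05 10^-6 cm/s in this assay, at which 1 of the 4 values shown sits.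

The compounds shown carry only the unsubstituted phenyl or a tetrafluorophenyl at the end of the chain, which leaves open how a monofluorophenyl or a pentafluorophenyl would read in this assay. Also open, from the compounds shown here alone, is whether the two tetrafluorophenyl patterns would still read alike with the alkyne of compound 2 or with a longer chain, as compound 2 differs from compound 3 and compound 4 in more than one place.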